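A larger group on a sulfur in an inactive pair

A few compounds are considered here, and "the series" means these few. Any claim that something is new, unique, unknown or untested is made for them only; others in the source may bear on it.

Measured in a functional assay on MCF7 cells (Homo sapiens) for inhibition, read by MTT assay, with a stated time of 72 h; on this read-out lower numbers stand for stronger inhibition and higher numbers for weaker inhibition:
Compound 1 `FC(F)(F)c1ccc(CSc2nc(Sc3ncccn3)cc(C(F)(F)F)n2)cc1`: > 50000 nM
Compound 2 `Cc1nnc(Sc2cc(C(F)(F)F)nc(SCc3ccc(C(F)(F)F)cc3)n2)s1`: > 50000 nM

Compound 1 stands at > 50000 nM, which is a limit of the assay and not a number. Compound 2 likewise stands only at a limit, > 50000 nM.

Compound 3 `FC(F)(F)c1ccc(CSc2nc(Sc3ncc(-c4ccncc4)s3)cc(C(F)(F)F)n2)cc1` keeps the rest of compound 2 and changes one group: 5-(pyridin-4-yl)-1,3-thiazol-2-yl comes in place of 5-methyl-1,3,4-thiadiazol-2-yl on a sulfur (5-(pyridin-4-yl)-1,3-thiazol-2-yl in place of 5-methyl-1,3,4-thiadiazol-2-yl on a sulfur).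

Among the measured compounds shown here, only one measured step bears on this change: a step that the two limits leave unreadable from compound 1 to compound 2. Its size cannot be read, since both compounds sit at the same ceiling: the limit of > 50000 nM in this assay, at which 2 of the 2 values shown sit. Swapping the group on this sulfur has therefore not yet produced a readable number in this assay, and weak inhibition is the plain expectation for the new compound. The expected change is an at least 1.2-fold lower number from compound 2 to compound 3 (0.09 log units; that floor lies within the scatter), which means no clear move in either direction is foreseen. Another limit would be no surprise. Compound 3 is estimated at 40000 nM, with an expected range from 10000 nM to 100000 nM.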

Compound 3, half-maximal inhibitory concentration: 10100 nM
The estimate for compound 3 lay 4.0-fold (0.60 log units) above the measured number, and the stated range covers the measured number.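

In this assay compound 3 gives 10100 nM, the only true number among the compounds shown. The group on this sulfur can therefore bring a compound in this series off the limit of the assay, where the others remain: the limit of > 50000 nM in this assay, at which 2 of the 3 values shown sit.

Placing 5-(pyridin-4-yl)-1,3-thiazol-2-yl on this sulfur in place of 5-methyl-1,3,4-thiadiazol-2-yl gives an at least 4.9-fold lower number from compound 2 to compound 3 (0.69 log units; beyond the scatter), and placing it there instead of pyrimidin-2-yl gives an at least 4.9-fold lower number from compound 1 to compound 3 (0.69 log units; beyond the scatter). Both steps start from a limit of the assay and are floors, while the step between compound 1 and compound 2 cannot be read.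

The entering group differs from the two earlier groups in more than one feature at once, as it brings both a different five-membered ring and a pyridin-4-yl ring, and the compounds shown cannot say which of these parts matters. From the compounds shown here alone, what a plain 1,3-thiazol-2-yl group or a 5-phenyl-1,3-thiazol-2-yl group would give on this sulfur stays open, and either would help to separate the two parts.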